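Shortening the Chain from Compound 2 to Compound 4

A few compounds are considered here, and "the series" means these few. Any claim that something is new, unique, unknown or untested is made for them only; others in the source may bear on it.

compound 1 `CCCc1cc(-c2ccc(F)cc2)nn1Cc1ccc(C(=O)NO)cc1`: 107 nM
compound 2 `O=C(CCCCCNC(=O)c1cc(-c2ccc(F)cc2)[nH]n1)NO`: 29 nM
compound 3 `Cc1cc(-c2ccc(F)cc2)nn1Cc1ccc(C(=O)NO)cc1`: 8 nM

Of the compounds shown here, three have been measured in an assay on cells for inhibition of protein deacetylase HDAC6 (Homo sapiens), read by fluorescence, with stated times of 15 min and 60 min; on this read-out higher numbers stand for weaker inhibition and lower numbers for stronger inhibition. Compound 2 gives 29 nM, the second highest of the three numbers, lying between compound 1 at 107 nM and compound 3 at 8 nM, and both of those gaps are beyond the scatter. Within the data shown here, the only measured step, a 13-fold lower number from compound 1 to compound 3 (1.13 log units; beyond the scatter), concerns the group on the core of compound 1 and not the chain that carries the hydroxamic acid.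

Compound 4 `O=C(CCNC(=O)c1cc(-c2ccc(F)cc2)[nH]n1)NO` is not yet measured. It differs from compound 2 by hydroxycarbamoyl in place of 3-(hydroxycarbamoyl)propyl on a saturated chain carbon, two bonds along the chain from an amide-type nitrogen. Among the measured compounds shown here, no measured step touches this chain, so there is nothing to lean on directly; the step of a 13-fold lower number from compound 1 to compound 3 (1.13 log units; beyond the scatter) shows only that small changes can move the number a long way. With the chain cut down this far, compound 4 is expected to give a weaker number than compound 2, a step of a 14-fold higher number from compound 2 to compound 4 (1.14 log units; beyond the scatter). The estimate for compound 4 is 400 nM, with a range from 60 nM to 3000 nM.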

Compound 4, half-maximal inhibitory concentration: > 5000 nM
Compound 4 ended at the assay's limit; the forecaster's own chance of this, stated with the estimate: 10%; middle value at least 12-fold (1.09 log units) away from the limit.
By their numbers in this assay, from the lowest: compound 3; then compound 2; then compound 1. At a limit, above all of these: compound 4.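

In this assay, compound 4 stands at a limit and not at a number: the limit of > 5000 nM in this assay, at which 1 of the 4 values shown sits. Cutting 3-(hydroxycarbamoyl)propyl back to hydroxycarbamoyl, with the rest of the structure unchanged, gives an at least 170-fold higher number from compound 2 to compound 4 (2.23 log units; beyond the scatter), and this is the only measured step on the chain that carries the hydroxamic acid. The earlier step, a 13-fold lower number from compound 1 to compound 3 (1.13 log units; beyond the scatter), concerned a group on the core, so only this new result shows that the number also depends strongly on the length of this chain.

Going by these compounds, how the number runs at chain lengths between those of compound 4 and compound 2, or with a longer chain, remains open. Also open, on these data alone, is what a carboxylic acid in place of hydroxycarbamoyl would give on the chain of compound 2.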